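The compounds below may be only part of what the source reports. "The series", "measured", "known", "first", "only" and "open" are said of these compounds alone.

Measured in an ADME assay on CCRF-CEM cells (Homo sapiens) for antiproliferative activity, with a stated time of 48 h; a lower number here means a stronger inhibitor, a higher number a weaker inhibitor:
- compound 1 `C=C(Br)C(=O)Nc1ccc(C(=O)/C=C/c2ccc(OC)cc2)cc1`: 1100 nM
- compound 2 `C=C(Br)C(=O)Nc1ccc(C(=O)/C=C/c2ccccc2OC)cc1`: 580 nM
- compound 3 `C=C(Br)C(=O)Nc1ccc(C(=O)/C=C/c2cccc(OC)c2OC)cc1`: 710 nM

Compound 1, at 1100 nM, cannot be separated from the other two compounds, as its value lies within the scatter of both. Among the measured compounds shown here, the series so far therefore shows no clear ranking in this assay.

Compound 4 `C=C(Br)C(=O)Nc1ccc(C(=O)/C=C/c2ccc(OC)c(OC)c2)cc1` is compound 1 with methoxy in place of hydrogen on an aromatic carbon, ortho to a methoxy group: methoxy in place of hydrogen on an aromatic carbon. For the measured compounds named here, the closest precedent is the same kind of replacement in a different place, a 1.2-fold higher number from compound 2 to compound 3 (0.09 log units; within the scatter). That step stays within the scatter. The step of a 1.9-fold lower number from compound 1 to compound 2 (0.28 log units; within the scatter) moves a methoxy group rather than adding one, so it bears on the question only loosely, and it also stays within the scatter. Neither step points to a firm direction, so no change beyond the scatter is expected in this assay. Since compound 1 has the top number of a narrow set, a value nearer the other two seems slightly more likely. The expected result is a 1.3-fold lower number from compound 1 to compound 4 (0.11 log units; within the scatter).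

For compound 4 the estimated value is 850 nM, with an expected range from 400 nM to 1800 nM.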

Compound 4, half-maximal inhibitory concentration: 1600 nM
For compound 4 the middle estimate is 1.9-fold (0.27 log units) below the measured one; low and high end bracket the measured number.
By their numbers in this assay, from the lowest: compounds 2, 3, 1 and 4 (each within the scatter of the next, the first and the last beyond it).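

In this assay, methoxy in place of hydrogen on an aromatic carbon, ortho to a methoxy group and meta to a large group, gives a 1.5-fold higher number from compound 1 to compound 4 (0.16 log units; within the scatter), so compound 4 cannot be separated from compound 1. Until now, the only case of this replacement was at another place on another core, and this result adds a second reading at a new position, ortho to the methoxy group that compound 1 already carries. The two readings agree, so in the compounds shown the added methoxy leaves the number within the scatter at both places, and the size of the step does not depend measurably on where it is added: the same change on two cores in this assay, a 1.2-fold higher number (0.09 log units; within the scatter) from compound 2 to compound 3 and a 1.5-fold higher number (0.16 log units; within the scatter) from compound 1 to compound 4, 1.2-fold (0.07 log units) apart, within the scatter of two such steps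

The compounds shown leave open whether any replacement at this position can move the number beyond the scatter, since methoxy is the only group that enters here, and a hydroxyl, a fluorine, an amine or a carboxylic acid might behave differently. They also leave open whether a longer chain on that oxygen, such as ethoxy, would keep the number within the scatter of compound 1.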